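The source may report more compounds than this note shows. Statements on the series, on what has been measured and on what is new or still open speak of the compounds shown alone.

Compound 3 `CCc1sc(CCc2cc(OCC3(C)CC3)cc(NCc3cc(Cl)cc(NC(=O)OC(C)C)c3)n2)nc1C` stands highest of the three numbers in an assay on cells for binding affinity to Neuropeptide Y receptor type 1 (Homo sapiens) (a higher number here means a weaker inhibitor, a lower number a stronger inhibitor), where it gives 17 nM; compound 1 `CCCCOc1cc(CCc2nc(C)c(CC)s2)nc(NCc2cc(Cl)cc(NC(=O)OC(C)C)c2)c1` gives 16 nM, so that a 1.1-fold higher number from compound 1 to compound 3 (0.03 log units; within the scatter), while compound 2 `CC/C=C\CCOc1cc(CCc2nc(C)c(CC)s2)nc(NCc2cc(Cl)cc(NC(=O)OC(C)C)c2)c1` gives 4.7 nM and a 3.6-fold higher number from compound 2 to compound 3 (0.56 log units; beyond the scatter). Compound 4 `CCc1sc(CCc2cc(OC3CCCC3)cc(NCc3cc(Cl)cc(NC(=O)OC(C)C)c3)n2)nc1C` differs from compound 3 only in the group on the ring oxygen: cyclopentyl in place of (1-methylcyclopropyl)methyl on an oxygen on an aromatic ring. Going by the values given here, the two earlier steps at this same position are the only guides, one within the scatter and the other modest, as a 3.4-fold lower number from compound 1 to compound 2 (0.53 log units; beyond the scatter) also shows for a change further along that chain. Among the compounds with values here, a cyclopentyl here has no direct precedent, so compound 4 is expected near compound 3, with an estimated 1.4-fold lower number from compound 3 to compound 4 (0.15 log units; within the scatter). Compound 4 is therefore estimated at 12 nM in this assay, in the range 5 nM to 35 nM.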

Compound 4, half-maximal inhibitory concentration: 11 nM
Beside the measured number, compound 4's estimate is 1.1-fold (0.04 log units) above it, and the stated range covers the measured number.
By their numbers in this assay, from the lowest: compound 2; then compounds 4, 1 and 3 (each within the scatter of the next).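

In this assay cyclopentyl on the oxygen on the aromatic ring cannot be told apart from the open butyl or the (1-methylcyclopropyl)methyl, with a 1.5-fold lower number from compound 1 to compound 4 (0.16 log units; within the scatter) and a 1.5-fold lower number from compound 3 to compound 4 (0.19 log units; within the scatter). Only the hex-3-en-1-yl stands apart, with a 2.3-fold higher number from compound 2 to compound 4 (0.37 log units; beyond the scatter), so among these four compounds, compound 2 alone separates from the rest. Nothing given here explains these numbers. Whether the double bond of compound 2 or its longer chain accounts for its separation stays open. So does the effect of an amine or a hydroxyl on the cyclopentyl.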